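The source may report more compounds than this note shows. Statements on the series, on what has been measured and on what is new or still open speak of the compounds shown alone.

Compound 3 `CCc1cccc2c(OC)c(-c3occ(C)c3C(=S)OC)ccc12` gives 6.2 ug/mL in a functional assay on A549 cells (Homo sapiens) for cytotoxicity, read by MTT assay, with a stated time of 72 h; a lower number here means that less compound is needed, a higher number that more compound is needed for the effect. Going by the values given here, of the two numbers the series so far yields, that of compound 3 is the highest; its nearest neighbour is compound 1 `CCOC(=O)c1c(C)coc1-c1ccc2c(CC)cccc2c1OC`, which in this assay gives 3.8 ug/mL, and the gap is a 1.6-fold higher number from compound 1 to compound 3 (0.21 log units; within the scatter). Compound 2 `CCCOC(=O)c1c(C)coc1-c1ccc2c(CC)cccc2c1OC` gives in this assay only a limit, > 10 ug/mL, the one noted as the limit of > 10 ug/mL in this assay, at which 1 of the 3 values shown sits. Compound 4 `CCc1cccc2c(OC)c(-c3occ(C)c3COC)ccc12` differs from compound 3 in a single place: a group of 3 heavy atoms (2 carbon, 1 oxygen; no ring) in place of a group of 4 heavy atoms (2 carbon, 1 oxygen, 1 sulfur; no ring), on an aromatic carbon. Among the compounds with values here, no measured step removes the thiocarbonyl itself; the steps that touch this position are an at least 1.6-fold lower number from compound 2 to compound 3 (0.20 log units; that floor lies within the scatter) and an at least 2.6-fold higher number from compound 1 to compound 2 (0.42 log units; beyond the scatter), of which only the latter lies beyond the scatter, and it points to a higher number when the chain at this position grows. The entering methoxymethyl carries no thiocarbonyl, so nothing measured fixes a direction, and compound 4 is expected to show a step of a 1.1-fold higher number from compound 3 to compound 4 (0.05 log units; within the scatter), at most modest. The estimate for compound 4 in this assay is 7 ug/mL, with a range from 3 ug/mL to 16 ug/mL.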

Compound 4, concentration for half-maximal effect: > 10 ug/mL
Compound 4: no number, only a limit; the forecaster's own chance of this, stated with the estimate: 30%; middle value at least 1.4-fold (0.15 log units) from the limit.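

In this assay compound 4 yields only a limit, and a second compound now sits there with compound 2: the limit of > 10 ug/mL in this assay, at which 2 of the 4 values shown sit. With methoxymethyl in place of ethoxycarbonyl on this aromatic carbon, the result is an at least 2.6-fold higher number from compound 1 to compound 4 (0.42 log units; beyond the scatter), so this position now shows a step beyond the scatter from a change that shortens the substituent, whereas the earlier step beyond the scatter came from lengthening the chain. Against the thiocarbonyl-bearing group the change gives an at least 1.6-fold higher number from compound 3 to compound 4 (0.20 log units; that floor lies within the scatter), and the step between the two limits cannot be read.

On these data alone, how far compound 2 and compound 4 lie past their limits remains open, so the two cannot be ranked. Also open, as far as these compounds go, is whether a carboxylic acid or an aminomethyl group on this carbon would return a measurable number.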